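Changing one aromatic group: expected clearance of compound 3

The compounds below may be only part of what the source reports. "The series", "measured", "known", "first", "only" and "open" are said of these compounds alone.

Compound 1 `Nc1ccc(S(=O)(=O)N2CCN(c3ncc(C(O)(C(F)(F)F)C(F)(F)F)cc3C#CCO)CC2)cn1`: < 14 mL.min-1.g-1
Compound 2 `COc1ccc(-c2cc(C(O)(C(F)(F)F)C(F)(F)F)cnc2N2CCN(S(=O)(=O)c3ccc(N)nc3)CC2)cn1`: 25 mL.min-1.g-1

Among the measured compounds shown here, in an ADME assay (liver) for metabolic stability, with Liver microsome (Homo sapiens) as the target, using microsomes and NADPH, with a stated time of 30 min, tested at 1 uM (a lower number here means slower removal, a higher number faster removal of the compound), compound 2 gives 25 mL.min-1.g-1, the only true number so far. Compound 1 gives < 14 mL.min-1.g-1, which is a limit of the assay and not a number.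

For the measured compounds named here, the one measured step is an at least 1.7-fold higher number from compound 1 to compound 2 (0.25 log units; that floor lies within the scatter). Its floor lies within the scatter, so it sets no firm size for a change at this place.

Compound 3 `Nc1ccc(S(=O)(=O)N2CCN(c3ncc(C(O)(C(F)(F)F)C(F)(F)F)cc3-c3ccc4c(c3)CC(=O)N4)CC2)cn1` differs from compound 2 in one group: a group of 10 heavy atoms (8 carbon, 1 nitrogen, 1 oxygen; one five-membered non-aromatic ring with 1 hetero atom, one six-membered aromatic ring of carbon only) in place of a group of 8 heavy atoms (6 carbon, 1 nitrogen, 1 oxygen; one six-membered aromatic ring with 1 hetero atom), on an aromatic carbon. Going by the values given here, no measured step involves the entering group, so the value of compound 2, 25 mL.min-1.g-1, is the best starting point, and no step beyond the scatter is expected.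

The estimated change is a 1.1-fold lower number from compound 2 to compound 3 (0.06 log units; within the scatter).

For compound 3 the expected value is 22 mL.min-1.g-1, with an estimated range from 10 mL.min-1.g-1 to 48 mL.min-1.g-1.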

Compound 3, intrinsic clearance in microsomes: < 14 mL.min-1.g-1
Compound 3 gave a limit, no number; the forecaster's own chance of this, stated with the estimate: 20%; middle value at least 1.5-fold (0.19 log units) from the limit.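

In this assay, compound 3 returns a limit of the assay, not a number. The change of group gives an at least 1.7-fold lower number from compound 2 to compound 3 (0.25 log units; that floor lies within the scatter), so the true gap may be larger, but it is not shown to exceed the usual scatter. What is new is that a ring group at this aromatic carbon, ortho to a large group, does not have to give a readable clearance: the 6-methoxypyridin-3-yl group of compound 2 did, while the two-ring group of compound 3 did not.

As far as these compounds go, the step from compound 1 to compound 3 cannot be read, because both compounds stand at the same limit: the limit of < 14 mL.min-1.g-1 in this assay, at which 2 of the 3 values shown sit. Whether a plain phenyl ring, or a pyridine ring carrying an amine in place of the methoxy group, would give a number at this carbon stays open.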